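The source may hold more compounds than are shown below. What is called first, only, known or untested is meant among the compounds shown, and "the series" means these compounds.

Measured so far:
Compound 1 `CNc1cc(Oc2c(C)cc(NC(=O)Nc3cccc(C(F)(F)F)c3)cc2C)ncn1`: in an assay on isolated protein for inhibition of serine/threonine-protein kinase TNNI3K (Homo sapiens) (a higher number here means a weaker inhibitor, a lower number a stronger inhibitor), compound 1 gives 25 nM.
Compound 2 `CNc1cc(Oc2ccc(NC(=O)Nc3cccc(C(F)(F)F)c3)cc2C)ncn1`: in this assay compound 2 gives <= 10 nM, which is a limit of the assay rather than a number.
Compound 3 `CNc1cc(Oc2ccc(NC(=O)Nc3cccc(C(F)(F)F)c3)cc2F)ncn1`: in this assay compound 3 gives 25 nM.

Compound 2 thus stands at the limit of <= 10 nM in this assay, at which 1 of the 3 values shown sits, so how far its true potency lies beyond that bound is not known. Compound 4 `CNc1cc(Oc2cc(C)c(NC(=O)Nc3cccc(C(F)(F)F)c3)cc2C)ncn1` differs from it by methyl in place of hydrogen on an aromatic carbon. Among the measured compounds shown here, two measured steps touch this change. Going an at least 2.5-fold lower number from compound 1 to compound 2 (0.39 log units; beyond the scatter), removal of a methyl from the shared core improved the number, though that methyl sat at a different place from the one entering in compound 4. Going an at least 2.5-fold higher number from compound 2 to compound 3 (0.39 log units; beyond the scatter), swapping the remaining methyl for fluoro weakened the compound. Neither step tests a methyl entering at the place described for compound 4, so the size of the step in this assay is uncertain; because compound 2 already sits at the limit of <= 10 nM in this assay, at which 1 of the 3 values shown sits, an improvement could not register as a number. A small weakening, near the edge of the scatter, is expected: an at least 1.2-fold higher number from compound 2 to compound 4 (0.07 log units; that floor lies within the scatter). Compound 4 is therefore estimated at 12 nM, with a range from 4 nM to 40 nM.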

Compound 4, half-maximal inhibitory concentration: 32 nM
Estimate against measurement, compound 4: 2.7-fold (0.43 log units) below, within the range that was stated.
By their numbers in this assay, from the lowest: compounds 1, 3 and 4 (each within the scatter of the next). At a limit, below all of these: compound 2.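

In this assay, a methyl entering on the aromatic carbon ortho to a large group and para to a methyl group gives an at least 3.2-fold higher number from compound 2 to compound 4 (0.50 log units; beyond the scatter). The earlier steps shown here concerned methyl at another place on the shared core, whereas this step shows that adding methyl at this position raises the number beyond the scatter. Compound 2 stands at a limit of the assay and not at a number, so this step is only a floor and the true change may be larger: the limit of <= 10 nM in this assay, at which 1 of the 4 values shown sits.

On these data alone, whether a fluoro, a methoxy or an amine on this same carbon would raise the number as methyl does remains open. As far as these compounds go, it is also open whether an ethyl or a longer chain here would raise it further than methyl.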